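Swapping an aryl amine for a benzyl amine on a shared core

The source may hold more compounds than are shown below. What is called first, only, known or untested is meant among the compounds shown, and "the series" means these compounds.

Compound 1 `COc1cc(Nc2ncccc2-c2n[nH]c(Nc3ccc(C#N)cc3)n2)cc(OC)c1` has no result in a functional assay on A-431 cells (Homo sapiens), tested at 0.1 uM; a lower number here means less inhibition, a higher number more inhibition at the concentration tested (going by the name of the read-out): in this assay compound 1 is recorded as "not determined" (no result reported), so no figure can be given for it. Compound 2 `COc1cc(Nc2ncccc2-c2n[nH]c(Nc3ccc4c(c3)OCCO4)n2)cc(OC)c1` carries a different group on the right-hand amine, and in this assay compound 2 gives 83%. For the measured compounds named here, since this is the only number available, compound 2 stands alone as the reference point, with nothing to rank it against.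

Compound 3 `Fc1ccc(CNc2ncccc2-c2n[nH]c(Nc3ccc4c(c3)OCCO4)n2)cc1F` is the next step from compound 2. The change is 3,4-difluorobenzyl in place of 3,5-dimethoxyphenyl on a nitrogen on an aromatic ring. Going by the values given here, no comparable pair has been measured, so the size of the step cannot be read off earlier data.

In this assay a step of this kind, which both removes the two oxygen acceptors and inserts an extra carbon between the nitrogen and the ring, is expected to cost inhibition, with the step of a number 33 percentage points lower from compound 2 to compound 3 (beyond the scatter) estimated to lie beyond the scatter and downward. Compound 3 is therefore expected to give about 50%, with a plausible range from 15% to 85%.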

Compound 3, a percentage reported as inhibition, at one concentration (the size of the read-out at that concentration, not a potency): 32%
Beside the measured number, compound 3's estimate is 18 percentage points above it; measured number inside the range.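

In this assay, the group on the nitrogen on an aromatic ring clearly matters: placing 3,4-difluorobenzyl there instead of 3,5-dimethoxyphenyl gives a number 51 percentage points lower from compound 2 to compound 3 (beyond the scatter). For the compounds shown here, this is the first comparison to show that this position responds at all, since compound 1 has no figure and so its difference from compound 2 cannot be read. The exchange alters several features at once, so the step belongs to the whole change from (3,5-dimethoxyphenyl)amino to (3,4-difluorobenzyl)amino and cannot be divided among its parts, and no measurement shown here explains the drop.

From the compounds shown here alone, it remains open whether a 3,5-dimethoxybenzyl or a 3,4-difluorophenyl group on that nitrogen would fall nearer compound 2 or compound 3, and either one would separate the effect of the benzyl link from that of the ring's substituents. It is also unknown how a group of a different kind, such as a longer chain ending in an amine, would fare at this position.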